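A Chloro Substituent Added to a Weakly Cytotoxic Core

This account rests on a few compounds, and the source may have more. Where it says the series, first, only, none or still open, it means among the compounds named here.

Compound 1 `Cc1ccc(Cc2cn3cc(Cl)ccc3nc2=O)cc1`: > 1000000 nM, a limit of the assay, not a number.
Compound 2 `O=c1nc2ccccn2cc1Cc1ccc(F)cc1`: 200000 nM.

Going by the values given here, in a functional assay on MCF7 cells (Homo sapiens) for cytotoxicity, read by MTT assay, with a stated time of 24 h (on this read-out lower numbers stand for stronger inhibition and higher numbers for weaker inhibition), compound 2 gives the only actual number here, 200000 nM. The other value, that of compound 1, is a limit. Compound 3 `O=c1nc2ccc(Cl)cn2cc1Cc1ccc(F)cc1` differs from compound 2 by chloro in place of hydrogen on an aromatic carbon. Among the compounds with values here, no measured pair isolates this change. Compound 1 also carries chloro and sits at the limit of > 1000000 nM in this assay, at which 1 of the 2 values shown sits. The step of a 2.0-fold higher number from compound 2 to compound 3 (0.30 log units; within the scatter) is expected to be modest, toward weaker inhibition. Compound 3 is therefore estimated at 400000 nM, within 100000 nM to 2000000 nM, with a fair chance of only a limit.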

Compound 3, half-maximal inhibitory concentration: 10400 nM
Beside the measured number, compound 3's estimate is 38-fold (1.59 log units) above it, and the stated range ends above it.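

In this assay, chloro in place of hydrogen on an aromatic carbon, two atoms from the ring nitrogen, gives a 19-fold lower number from compound 2 to compound 3 (1.28 log units; beyond the scatter), so this change at this position goes toward stronger inhibition. The value of compound 1 is a limit of the assay and not a number: the limit of > 1000000 nM in this assay, at which 1 of the 3 values shown sits. With chloro in both compounds, fluoro in place of methyl on an aromatic carbon gives an at least 96-fold lower number from compound 1 to compound 3 (1.98 log units; beyond the scatter), so chloro alone does not set the read-out.

Going by these compounds, whether an amine, a methoxy group or a carboxylic acid at the chloro position would act the same stays open. So does how methyl in place of fluoro acts without chloro.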